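This account rests on a few compounds, and the source may have more. Where it says the series, first, only, none or still open, it means among the compounds named here.

In an assay on HEK293F cells for inhibition of cholesterol 24-hydroxylase (Homo sapiens), read by trypan blue exclusion, with stated times of 15 min and 5 h (on this read-out higher numbers stand for weaker inhibition and lower numbers for stronger inhibition), compound 1 `CN(C)C(=O)C1CCN(c2cnccc2-c2ccccn2)CC1` gives 68 nM, while compound 2 `CN(C)C(=O)C1CCN(c2cnccc2-n2cc(C3CC3)cn2)CC1` gives 12 nM. Among the compounds with values here, of the two numbers measured so far, compound 2 stands at the lowest; its nearest neighbour is compound 1, and the step of a 5.7-fold lower number from compound 1 to compound 2 (0.75 log units; beyond the scatter) separates them, a change that came with the 4-cyclopropyl-1H-pyrazol-1-yl taking the place of the pyridin-2-yl on the aromatic carbon.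

Compound 3 `Cc1cnc(-c2ccncc2N2CCC(C(=O)N(C)C)CC2)s1` has not yet been measured in this assay. It differs from compound 2 in one place: 5-methyl-1,3-thiazol-2-yl in place of 4-cyclopropyl-1H-pyrazol-1-yl on an aromatic carbon. Within the data shown here, the only step that bears on this change is the one from compound 1 to compound 2, which showed that swapping one aromatic ring for another at this position can move the number by a modest amount. That step does not involve a thiazolyl, so nothing measured here points directly to the size or direction of the present change. In this assay compound 3 is therefore expected to land near compound 2, with the estimated step of a 2.1-fold higher number from compound 2 to compound 3 (0.32 log units; beyond the scatter) taken to be small and somewhat toward a higher number. The estimate for compound 3 in this assay is 25 nM, with a range from 8 nM to 80 nM.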

Compound 3, half-maximal inhibitory concentration in the cholesterol 24-hydroxylase assay: 12 nM
For compound 3 the middle estimate is 2.1-fold (0.32 log units) above the measured one, and the stated range covers the measured number.
By their numbers in the cholesterol 24-hydroxylase assay, from the lowest: compounds 2 and 3 (each within the scatter of the next); then compound 1.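

In the cholesterol 24-hydroxylase assay, the 5-methyl-1,3-thiazol-2-yl serves this position on the shared core as well as the 4-cyclopropyl-1H-pyrazol-1-yl, with compound 2 at 12 nM and compound 3 at 12 nM, and with no change at the digits printed from compound 2 to compound 3 (within the scatter), even though the three-membered ring of carbon leaves with the outgoing group and a sulfur enters. The advantage seen earlier over the pyridin-2-yl is thus not confined to the pyrazolyl group, since the cholesterol 24-hydroxylase assay also shows a 5.7-fold lower number from compound 1 to compound 3 (0.75 log units; beyond the scatter), so among these three compounds both five-membered aromatic rings with 2 hetero atoms give lower numbers than the pyridin-2-yl. The same exchange between the two five-membered rings also leaves a physicochemical assay for lipophilicity, at pH 7.4 (a higher number here means a more lipophilic compound, a lower number a more polar compound), without a meaningful shift, with compound 2 at 2.1 and compound 3 at 2, and with a number 0.10 log units lower from compound 2 to compound 3 (within the scatter), so these two groups cannot be told apart on either read-out.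

Going by these compounds, how a thiazol-2-yl without its methyl, or an amine or a carboxylic acid on this aromatic carbon, would read in the cholesterol 24-hydroxylase assay remains open, and so does how much the methyl or the cyclopropyl contributes to these numbers. Nothing on hand accounts for why the two groups give matching numbers.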